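The source may hold more compounds than are shown below. What is called first, only, known or untested is meant among the compounds shown, and "the series" means these compounds.

Measured compounds:
Compound 1, `COCc1cc(OC)c(-c2cccc3c(N(CC4CC4)CC4OCCCO4)c(SC)nn23)c(OC)c1`, gives 113 nM in an assay on HEK293 cells for displacement of a labelled ligand from corticotropin-releasing factor receptor 1 (Homo sapiens), read by scintillation counting, with a stated time of 2 h; on this read-out higher numbers stand for weaker inhibition and lower numbers for stronger inhibition.
Compound 2, `CCc1nn2c(-c3c(C)cc(C)cc3OC)cccc2c1N(CC1CC1)CC1CCCO1`, gives 34 nM in this assay.
Compound 3, `CCc1nn2c(-c3c(OC)cc(C)cc3OC)cccc2c1N(CC1CCOCC1)CC1CC1`, gives 22 nM in this assay.

The three compounds share one core, and the numbers above describe how strongly each displaces the labelled ligand. Compound 2 stands second highest of the three. Its value and that of compound 3 lie within the usual scatter of each other, so nothing can be said about their order. Compound 1, however, gives a number that is clearly higher than that of compound 2, beyond the scatter.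

Compound 4, `CCc1nn2c(-c3c(C)cc(C)cc3OC)cccc2c1N(CCCF)CC1CC1`, has not yet been measured. It differs from compound 2 in one place: 2-fluoroethyl in place of oxolan-2-yl on a saturated chain carbon bound to a nitrogen on an aromatic ring. The group that leaves carries a ring and a hydrogen-bond acceptor; the group that enters carries neither. Going by the values given here, no measured pair in this set shows what such a change does in this assay, so there is no step to lean on.

On that basis the expectation is a modest shift, and the estimated step of a 1.2-fold higher number from compound 2 to compound 4 (0.07 log units; within the scatter) is judged to stay close to the scatter. Compound 4 is therefore expected to give about 40 nM, within a range from 15 nM to 120 nM.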

Compound 4, half-maximal inhibitory concentration: 20 nM
Compound 4: middle estimate off by 2.0-fold (0.30 log units), on the high side; the range from low to high includes it.
By their numbers in this assay, from the lowest: compounds 4, 3 and 2 (each within the scatter of the next); then compound 1.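

Going by these compounds alone, compound 2 and compound 4 are the first pair in this set that differ in only one place, so they give the first direct look at this position. On the saturated chain carbon bound to a nitrogen on an aromatic ring, putting 2-fluoroethyl in place of oxolan-2-yl gives a 1.7-fold lower number from compound 2 to compound 4 (0.23 log units; within the scatter) in this assay and the two compounds cannot be told apart. For this pair, then, the ring and the hydrogen-bond acceptor of the leaving group are not required for a value within the scatter of compound 2, and no measurement shown here offers an explanation for that.

The compounds shown leave open what the fluorine itself contributes, as a plain propyl chain at this place would be the direct comparison with compound 4, and a longer chain such as butyl would show how much length the position accepts. They also leave open how an amine or a carboxylic acid at the end of the chain would fare, and whether the same exchange gives a similar result on other versions of the shared core.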